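The source may hold more compounds than are shown below. What is called first, only, known or untested is meant among the compounds shown, and "the series" means these compounds.

Of the compounds shown here, two share one core and have been tested in an assay on HEK293 cells for displacement of a labelled ligand from metabotropic glutamate receptor 5 (Rattus norvegicus); a higher number here means a weaker inhibitor, a lower number a stronger inhibitor. Compound 1 `O=C(Nc1cc(-c2ccccc2)nn1-c1ccccc1)c1ccc(Cl)c(Cl)c1` carries a dichlorobenzamido group and gives 160 nM in this assay. Compound 2 `O=C(Nc1cc(-c2ccccc2)nn1-c1ccccc1F)c1ccccc1` has a plain benzamido group and a 2-fluorophenyl on the ring nitrogen, and in this assay compound 2 gives 2700 nM, the higher of the two numbers; compound 1 sits at a clearly lower number, a gap beyond the usual scatter. Since the two differ in more than one place, no single step can be read from them.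

Compound 3 `O=C(Nc1cc(-c2ccccc2)nn1-c1ccccn1)c1ccccc1` differs from compound 2 in one place: pyridin-2-yl in place of 2-fluorophenyl on an aromatic nitrogen. Nothing measured here shows what such an exchange does, so no step beyond the scatter is expected, and the expected change is a 1.2-fold lower number from compound 2 to compound 3 (0.09 log units; within the scatter). Compound 3 is therefore estimated at 2200 nM in this assay, within a range from 600 nM to 8000 nM.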

Compound 3, inhibition constant: > 10000 nM
Compound 3 ended at the assay's limit; the forecaster's own chance of this, stated with the estimate: 10%; middle value at least 4.5-fold (0.65 log units) away from the limit.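

Swapping the group on this aromatic nitrogen gives the first single change that can be read in the series: pyridin-2-yl in place of 2-fluorophenyl gives an at least 3.7-fold higher number from compound 2 to compound 3 (0.56 log units; beyond the scatter) in this assay. Among the compounds shown here, this position is therefore not indifferent to the group it carries, even though the two groups differ by only one ring atom and the fluorine, and compound 3 is the weaker inhibitor beyond the scatter. Compound 3 gives > 10000 nM, which is a limit of the assay and not a number, so the step has a lower bound but no known full size: the limit of > 10000 nM in this assay, at which 1 of the 3 values shown sits.

Going by these compounds, it remains open how a plain phenyl, a pyridin-3-yl or a small methyl group on this nitrogen would compare with the plain benzamido group kept in place. On these data alone, it is also open whether the dichlorobenzamido group of compound 1 would change the outcome of the same exchange.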